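Compound 4: 4-ethoxyphenyl on the nitrogen

The source may hold more compounds than are shown below. What is called first, only, known or untested is meant among the compounds shown, and "the series" means these compounds.

In a functional assay on MCF7 cells (Homo sapiens) for antiproliferative activity, read by MTT assay, with a stated time of 48 h (a lower number here means a stronger inhibitor, a higher number a weaker inhibitor), compound 1 `COc1ccc(-c2c(Nc3ccc(C)c(O)c3)c3ccccc3oc2=O)cc1` gives 12100 nM. Compound 3 `COc1ccc(-c2c(Nc3ccc(C)c(O)c3)c3ccc(OC)cc3oc2=O)cc1` gives 34400 nM, the higher of the two numbers, and methoxy in place of hydrogen on an aromatic carbon accounts for a 2.8-fold higher number from compound 1 to compound 3 (0.45 log units; beyond the scatter). Compound 2 `COc1ccc(-c2c(Nc3ccc(F)cc3)c3ccc(OC)cc3oc2=O)cc1` reads > 100000 nM, which is a limit of this assay and not a number.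

Compound 4 `CCOc1ccc(Nc2c(-c3ccc(OC)cc3)c(=O)oc3cc(OC)ccc23)cc1` carries 4-ethoxyphenyl in place of 3-hydroxy-4-methylphenyl on a nitrogen on an aromatic ring. The measured change at this same place bears most directly: 3-hydroxy-4-methylphenyl in place of 4-fluorophenyl gave an at least 2.9-fold lower number from compound 2 to compound 3 (0.46 log units; beyond the scatter). The methoxy step sits elsewhere on the core and bears only on the background level of the series. Compound 4 gives up the 3-hydroxy-4-methylphenyl of compound 3, so a modest move towards a higher number is expected in this assay, and a reading at the limit is possible. The estimated change is a 2.0-fold higher number from compound 3 to compound 4 (0.31 log units; beyond the scatter). For compound 4 the expected value is 70000 nM, with an estimated range of 25000 nM to 200000 nM.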

Compound 4, half-maximal inhibitory concentration: 24300 nM
Beside the measured number, compound 4's estimate is 2.9-fold (0.46 log units) above it; measured number outside the range, below it.
By their numbers in this assay, from the lowest: compounds 1, 4 and 3 (each within the scatter of the next, the first and the last beyond it). At a limit, above all of these: compound 2.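

In this assay, 4-ethoxyphenyl on the nitrogen, with no hydrogen-bond donor, stands in for 3-hydroxy-4-methylphenyl at a 1.4-fold lower number from compound 3 to compound 4 (0.15 log units; within the scatter), so a hydroxy group on this ring is not needed to match compound 3. Ethoxy in place of fluoro on an aromatic carbon gives an at least 4.1-fold lower number from compound 2 to compound 4 (0.61 log units; beyond the scatter), which shows that the separation from the 4-fluorophenyl compound also appears with a ring carrying no hydroxy group. The reading of compound 2 is a limit and not a number: the limit of > 100000 nM in this assay, at which 1 of the 4 values shown sits.

Whether the ethoxy chain can be extended is open, as is how a propoxy group, a dimethylamino group or a carboxylic acid at this place would read. Also open, as far as these compounds go, is whether the methoxy step on the core carries over to the 4-ethoxyphenyl series.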